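Sulfonamide Arm Replaces a Chloroalkyl Tail

The source may hold more compounds than are shown below. What is called first, only, known or untested is meant among the compounds shown, and "the series" means these compounds.

Three measured compounds share one core and differ only in the group fixed to one aromatic carbon. Compound 1 `COc1ccccc1-c1cn(C[C@H](O)[C@H]2OC(=O)C(OCc3ccccc3)=C2OCc2ccccc2)nn1` carries a 2-methoxyphenyl there. In a functional assay on HepG2 cells (Homo sapiens) for antiproliferative activity, read by MTT assay, with a stated time of 72 h (on this read-out lower numbers stand for stronger inhibition and higher numbers for weaker inhibition), compound 1 reaches only the limit of > 100000 nM, so no number is known for it (the limit of > 100000 nM in this assay, at which 1 of the 3 values shown sits). Compound 2 `CC(C)(C)c1cn(C[C@H](O)[C@H]2OC(=O)C(OCc3ccccc3)=C2OCc2ccccc2)nn1` carries tert-butyl and gives 29200 nM in this assay. Compound 3 `O=C1O[C@H]([C@@H](O)Cn2cc(CCCCl)nn2)C(OCc2ccccc2)=C1OCc1ccccc1` carries 3-chloropropyl and gives 35000 nM in this assay; this is the higher of the two real numbers, yet the gap to compound 2 is within the scatter, so the two count as alike. The steps read an at least 3.4-fold lower number from compound 1 to compound 2 (0.53 log units; beyond the scatter), an at least 2.8-fold lower number from compound 1 to compound 3 (0.45 log units; beyond the scatter) and a 1.2-fold higher number from compound 2 to compound 3 (0.08 log units; within the scatter).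

Compound 4 `Cc1ccc(S(=O)(=O)NCc2cn(C[C@H](O)[C@H]3OC(=O)C(OCc4ccccc4)=C3OCc3ccccc3)nn2)cc1` differs from compound 3 by ((4-methylphenyl)sulfonyl)amino in place of 2-chloroethyl on a saturated chain carbon bound to an aromatic carbon. Going by the values given here, the measured steps only show that a ring placed directly on the aromatic carbon gave a limit while the two alkyl groups gave numbers; compound 4 brings an aromatic ring back, but held away on a chain through a sulfonamide, and no measured step covers such an arm. The expectation for compound 4 is therefore a mild drift toward weaker, a 1.6-fold higher number from compound 3 to compound 4 (0.20 log units; within the scatter), which remains uncertain. Compound 4 is estimated at 55000 nM, within 18000 nM to 160000 nM.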

Compound 4, half-maximal inhibitory concentration: 24900 nM
The estimate for compound 4 lay 2.2-fold (0.34 log units) above the measured number; the range from low to high includes it.
By their numbers in this assay, from the lowest: compounds 4, 2 and 3 (each within the scatter of the next). At a limit, above all of these: compound 1.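

In this assay, ((4-methylphenyl)sulfonyl)amino in place of 2-chloroethyl on a saturated chain carbon bound to an aromatic carbon gives a 1.4-fold lower number from compound 3 to compound 4 (0.15 log units; within the scatter), and the comparison with the tert-butyl group gives a 1.2-fold lower number from compound 2 to compound 4 (0.07 log units; within the scatter), so this position tolerates a larger arm carrying a sulfonamide and an aromatic ring with no change that stands clear of the scatter. An aromatic ring at this position therefore need not end in a limit, as the step from the 2-methoxyphenyl group shows: an at least 4.0-fold lower number from compound 1 to compound 4 (0.60 log units; beyond the scatter). Compound 1 itself still gives no real number, only a limit: the limit of > 100000 nM in this assay, at which 1 of the 4 values shown sits.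

The compounds shown leave open whether the limit of compound 1 comes with any ring set directly on the aromatic carbon or only with the 2-methoxyphenyl group, which an unsubstituted phenyl group would help to separate. They also leave open whether anything at this position can move the number beyond the scatter from the three alike values, for example an amine or a carboxylic acid at the end of a longer chain.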